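From tert-butyl to benzyl on the shared core

This account rests on a few compounds, and the source may have more. Where it says the series, first, only, none or still open, it means among the compounds named here.

Values in a functional assay on SK-MEL-28 cells (Homo sapiens) for inhibition, read by MTT assay, with a stated time of 72 h; a higher number here means a weaker inhibitor of growth, a lower number a stronger inhibitor of growth:
- compound 1 `CCOC(=O)/C=C/C1=CC[C@H]2C(C)(C)CCC[C@]2(C)[C@H]1C=O`: 29000 nM
- compound 2 `CC(C)(C)OC(=O)/C=C/C1=CC[C@H]2C(C)(C)CCC[C@]2(C)[C@H]1C=O`: 41000 nM

Going by the values given here, only two numbers exist so far, and compound 2, at 41000 nM, lies within the scatter of compound 1. The next structure is compound 3 `CC1(C)CCC[C@]2(C)[C@@H](C=O)C(/C=C/C(=O)OCc3ccccc3)=CC[C@@H]12`, and the change is benzyl in place of tert-butyl on an oxygen next to a carbonyl group. Among the compounds with values here, one measured step bears on it, at the same place: a 1.4-fold higher number from compound 1 to compound 2 (0.15 log units; within the scatter). That step was small, but neither measured compound carries a ring at this place, so it is only a weak guide. No clear direction can be expected in this assay. The expected size is a 1.2-fold lower number from compound 2 to compound 3 (0.09 log units; within the scatter). The estimate for compound 3 is 33000 nM, with a range from 12000 nM to 80000 nM.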

Compound 3, concentration for 50% growth inhibition: 39000 nM
Beside the measured number, compound 3's estimate is 1.2-fold (0.07 log units) below it; the range from low to high includes it.
By their numbers in this assay, from the lowest: compounds 1, 3 and 2 (each within the scatter of the next).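

An aromatic ring on an oxygen next to a carbonyl group changes little in this assay: the data show a 1.1-fold lower number from compound 2 to compound 3 (0.02 log units; within the scatter) and a 1.3-fold higher number from compound 1 to compound 3 (0.13 log units; within the scatter). Ethyl, tert-butyl and benzyl therefore cannot be told apart here, even though benzyl adds one six-membered aromatic ring of carbon only and is larger than tert-butyl by its count of heavy atoms. No measured evidence accounts for this lack of separation. Still open, from the compounds shown here alone, is whether a chain ending in an amine or a carboxylic acid at this place would move the number beyond the scatter.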